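The source may hold more compounds than are shown below. What is called first, only, known or untested is meant among the compounds shown, and "the series" means these compounds.

Compound 2 `O=C(O)c1cnn(-c2cccc(-c3cccc(C(=O)N4CCCCC4)c3F)c2)c1C1CC1` and compound 1 `CCCC1CCCCN1C(=O)c1cccc(-c2cccc(-n3ncc(C(=O)O)c3C3CC3c3cccnn3)c2)c1` share a core and differ in their outer parts. In an assay on BEAS-2B cells for activation of nuclear factor erythroid 2-related factor 2 (Homo sapiens), read by MTT assay, with a stated time of 48 h (a higher number here means that more compound is needed for the effect, a lower number that less compound is needed), compound 2 gives 2300 nM, the smaller of the two numbers recorded, while compound 1 gives 2800 nM, a gap that lies within the scatter of such measurements. Compound 3 `CN(C)C(=O)c1cccc(-c2cccc(-n3ncc(C(=O)O)c3C3CC3)c2)c1F` is compound 2 with dimethylamino in place of piperidin-1-yl on a carbonyl carbon. Among the measured compounds shown here, no measured pair shows this change, so its effect is unknown; only a small shift in this assay, or none beyond the scatter, is expected. For compound 3 the expected value is 3000 nM, ranging from 1500 nM to 6000 nM, which is an expected step of a 1.3-fold higher number from compound 2 to compound 3 (0.12 log units; within the scatter).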

Compound 3, half-maximal effective concentration: 1300 nM
For compound 3 the middle estimate is 2.3-fold (0.36 log units) above the measured one, and the stated range ends above it.
By their numbers in this assay, from the lowest: compounds 3, 2 and 1 (each within the scatter of the next, the first and the last beyond it).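

Swapping piperidin-1-yl for dimethylamino on a carbonyl carbon gives a 1.8-fold lower number from compound 2 to compound 3 (0.25 log units; within the scatter) in this assay. At this position, then, the six-membered ring of piperidin-1-yl can be replaced by an open group without a shift that stands clear of the scatter. No measurement at hand offers an explanation for this step. The compounds shown leave open whether the same holds for other groups on this carbonyl carbon, such as methylamino, which keeps an amide hydrogen, or morpholin-4-yl, which brings oxygen into the ring.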